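Cyclopentenyl for Neopentyl on a Shared Core

The source may report more compounds than this note shows. Statements on the series, on what has been measured and on what is new or still open speak of the compounds shown alone.

Measured compounds:
Compound 1 `CC(C)(C)CCn1nc(CC(C)(C)C)c(O)c(C2=NS(=O)(=O)c3cc(NS(C)(=O)=O)ccc3N2)c1=O`: > 1000 nM
Compound 2 `CC(C)(C)Cc1nn(CCC2CC2)c(=O)c(C2=NS(=O)(=O)c3cc(NS(C)(=O)=O)ccc3N2)c1O`: > 1000 nM

In an ADME assay on Huh-7 cells (Homo sapiens) for cytotoxicity, with a stated time of 72 h (on this read-out higher numbers stand for lower toxicity in this test and lower numbers for higher toxicity in this test), compound 1 gives > 1000 nM, which is a limit of the assay rather than a number. Compound 2 likewise gives only a limit, > 1000 nM. For the measured compounds named here, the single measured step, a step that the two limits leave unreadable from compound 1 to compound 2, is thus unreadable, and compound 2 stands only at that limit. Compound 3 `CS(=O)(=O)Nc1ccc2c(c1)S(=O)(=O)N=C(c1c(O)c(C3=CCCC3)nn(CCC3CC3)c1=O)N2` differs from compound 2 by cyclopent-1-en-1-yl in place of neopentyl on an aromatic carbon. Going by the values given here, no measured step covers this change, and the limit of > 1000 nM in this assay, at which 2 of the 2 values shown sit, leaves the size of any shift unknown. Compound 3 is expected to stay at the limit, an estimated 2000 nM (range 700 nM to 8000 nM), an expected step that the limit leaves unreadable from compound 2 to compound 3.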

Compound 3, half-maximal cytotoxic concentration in the Huh-7 assay: > 1000 nM
Compound 3: only a limit was reported; the forecaster's own chance of this, stated with the estimate: 85%; the middle value is on the limit's open side.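

In a physicochemical assay for solubility, at pH 7.4 (on this read-out lower numbers stand for lower solubility and higher numbers for higher solubility), compound 2 gives > 100000 nM, which is a limit of the assay. In the physicochemical assay compound 3 gives > 100000 nM, again a limit. For the compounds shown here, no step between compound 2 and compound 3 can be read, either in the Huh-7 assay or in the physicochemical assay. Going by these compounds, how far either compound lies past these limits, and whether cyclopent-1-en-1-yl in place of neopentyl shifts either read-out at all, stays open.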